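The source may hold more compounds than are shown below. What is called first, only, known or untested is meant among the compounds shown, and "the series" means these compounds.

Of the compounds shown here, three with a carboxylic acid have so far been measured in a physicochemical assay for lipophilicity, measured as octanol-water partition, at pH 7.4; on this read-out higher numbers stand for higher lipophilicity and lower numbers for lower lipophilicity. Compound 1 (`Cc1cccc(C)c1-c1cccc(COc2ccc3c(c2)CCCC3CC(=O)O)c1`) gives 4.7, compound 2 (`Cc1cccc(C)c1-c1cccc(COc2ccc3c(CC(=O)O)coc3c2)c1`) gives 4.04, and compound 3 (`Cc1cccc(C)c1-c1cccc(COc2ccc3c(c2)OCC3CC(=O)O)c1`) gives 3.88. Compound 3 and compound 2 are level within the usual scatter of this kind of measurement, whereas compound 1 stands higher than compound 3 by a gap beyond that scatter.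

Compound 4 (`O=C(O)CC1COc2cc(OCc3cccc(-c4csc5ccccc45)c3)ccc21`) is still unmeasured. It has 1-benzothiophen-3-yl in place of 2,6-dimethylphenyl on an aromatic carbon of compound 3: 1-benzothiophen-3-yl in place of 2,6-dimethylphenyl on an aromatic carbon. Among the compounds with values here, all three measured compounds carry 2,6-dimethylphenyl, so the data contain no direct precedent for this swap, and any forecast remains uncertain. A small upward shift in this assay is expected, one that would stay within the scatter, and the estimated change is a number 0.17 log units higher from compound 3 to compound 4 (within the scatter). For compound 4 the estimated value is 4.05, with an expected range from 3.6 to 4.5.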

Compound 4, distribution coefficient: 3.99
Compound 4: middle estimate off by 0.06 log units, on the high side; low and high end bracket the measured number.
By their numbers in this assay, from the lowest: compounds 3, 4 and 2 (each within the scatter of the next); then compound 1.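

In this assay, putting 1-benzothiophen-3-yl in place of 2,6-dimethylphenyl gives a number 0.11 log units higher from compound 3 to compound 4 (within the scatter), so the two compounds are level on this read-out. Within the data shown here, this is the first measured change at this position, since every earlier compound carried 2,6-dimethylphenyl there, and it shows that this aromatic carbon can take a group with a five-membered aromatic ring holding sulfur without a reading that stands apart from compound 3. Nothing available explains why the two groups read alike.

One swap on one core says little about this position in general, and a group such as an amine or an amide there could behave quite differently. On these data alone, whether the same swap would also leave the reading level on the core of compound 1 or compound 2 remains open.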